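Replacing a Vinylsulfonyl Group with a Nitrile

This account rests on a few compounds, and the source may have more. Where it says the series, first, only, none or still open, it means among the compounds named here.

Compound 2 `C=CS(=O)(=O)c1cc(C(F)(F)F)cc(C(F)(F)F)c1` is the shortest-lived of the three measured compounds in an ADME assay for pharmacokinetics, read by LC-MS, in phosphate buffer, with a stated time of 72 h, at pH 7.4, tested at 250 uM; on this read-out lower numbers stand for a shorter-lived compound and higher numbers for a longer-lived compound. Its result there, < 0.017 h, is a limit of the assay rather than a number (the limit of < 0.017 h in this assay, at which 1 of the 3 values shown sits). Compound 1 `C=CC(=O)Nc1cc(C(F)(F)F)cc(C(F)(F)F)c1` gives 5.7 h in this assay, and compound 3 `C#Cc1cc(C(F)(F)F)cc(C(F)(F)F)c1` gives 0.3 h. Compound 4 `N#Cc1cc(C(F)(F)F)cc(C(F)(F)F)c1` differs from compound 2 by cyano in place of vinylsulfonyl on an aromatic carbon. Two measured steps start from or end at compound 2: an at least 330-fold lower number from compound 1 to compound 2 (2.52 log units; beyond the scatter) and an at least 17-fold higher number from compound 2 to compound 3 (1.24 log units; beyond the scatter). Both were large, and the second swaps the vinylsulfonyl group for another small unsaturated group, so a large rise in half-life is expected here as well, an at least 1100-fold higher number from compound 2 to compound 4 (3.07 log units; beyond the scatter). Compound 4 is estimated to reach 20 h, with a plausible range from 2 h to 200 h.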

Compound 4, half-life: > 50 h
Compound 4: no number, only a limit; the forecaster's own chance of this, stated with the estimate: 35%; at least 2.5-fold (0.39 log units) between middle value and limit.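

In this assay compound 4 gives > 50 h, which is a limit of the assay and not a number. On this aromatic carbon, cyano gives the longest-lived of the four compounds, with an at least 2900-fold higher number from compound 2 to compound 4 (3.46 log units; beyond the scatter) and an at least 8.7-fold higher number from compound 1 to compound 4 (0.94 log units; beyond the scatter). Ethynyl also holds a triple bond at this place, yet the swap to cyano still gives an at least 160-fold higher number from compound 3 to compound 4 (2.22 log units; beyond the scatter), so a triple bond alone does not set the half-life here.

The compounds shown leave open how long compound 4 actually lasts. They also leave open how an amine, a carboxylic acid or a longer chain would fare at this position.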